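Coumarin ester series: ethyl to methyl ester swap

This account rests on a few compounds, and the source may have more. Where it says the series, first, only, none or still open, it means among the compounds named here.

Compound 1 `CCOC(=O)c1cc2cc(C=O)cc(C(C)CC)c2oc1=O` gives 132000 nM in a functional assay on KB cells (Homo sapiens) for cytotoxicity, read by sulforhodamine B assay, with a stated time of 48 h; on this read-out lower numbers stand for stronger inhibition and higher numbers for weaker inhibition. Compound 3 `CCC(C)c1cc(C=O)cc2cc(C(=O)OC)c(=O)oc12` differs by hydrogen in place of methyl on a saturated chain carbon bound to an oxygen next to a carbonyl group and gives 146000 nM, a step of a 1.1-fold higher number from compound 1 to compound 3 (0.04 log units; within the scatter). Compound 2 `CCOC(=O)c1cc2cc(/C=C/C(=O)c3ccc(Cl)cc3)cc(C(C)CC)c2oc1=O` gives 14300 nM, the lowest of the three numbers, with steps to compound 1 and compound 3 that lie beyond the scatter; the difference between the core of compound 2 and the core of compound 1 is not broken down here. Compound 4 `CCC(C)c1cc(/C=C/C(=O)c2ccc(Cl)cc2)cc2cc(C(=O)OC)c(=O)oc12` differs from compound 2 by hydrogen in place of methyl on a saturated chain carbon bound to an oxygen next to a carbonyl group, the same change as from compound 1 to compound 3 at the same place. The step is expected to be a 1.1-fold higher number from compound 2 to compound 4 (0.03 log units; within the scatter), resting on the near-flat step from compound 1 to compound 3 of a 1.1-fold higher number from compound 1 to compound 3 (0.04 log units; within the scatter). Compound 4 is therefore estimated at 15500 nM.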

Compound 4, half-maximal inhibitory concentration: 28300 nM
Compound 4: middle estimate off by 1.8-fold (0.26 log units), on the low side, and the stated range covers the measured number.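

In this assay, the swap of ethoxycarbonyl to methoxycarbonyl on the enone-bearing core gives a 2.0-fold higher number from compound 2 to compound 4 (0.30 log units; within the scatter). Set beside the aldehyde pair, the step does not differ between the two cores: the same change on two cores in this assay, a 1.1-fold higher number (0.04 log units; within the scatter) from compound 1 to compound 3 and a 2.0-fold higher number (0.30 log units; within the scatter) from compound 2 to compound 4, 1.8-fold (0.25 log units) apart, within the scatter of two such steps

Within these two pairs, the swap carries from one core to the other with no step beyond the scatter. This does not show that the swap would stay this small on any other core, and two pairs set no rule for the series.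

The compounds shown leave open whether a longer chain on the ester, such as propoxycarbonyl, would keep the number in place. From the compounds shown here alone, a carboxylic acid or an amide in place of the ester also remains open.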